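Working notes on cytotoxicity across four analogues

The source may report more compounds than this note shows. Statements on the series, on what has been measured and on what is new or still open speak of the compounds shown alone.

Measured so far:
Compound 1, `CCCCCCCCOc1nc(N)nc2c1ncn2/C=C1/CC1(CO)CO` — in an ADME assay on CCRF-HSB-2 cells (Homo sapiens) for cytotoxicity, with a stated time of 7 days (on this read-out higher numbers stand for lower toxicity in this test and lower numbers for higher toxicity in this test), compound 1 gives > 20000 nM, which is a limit of the assay and not a number.
Compound 2, `CCCCSc1nc(N)nc2c1ncn2/C=C1/CC1(CO)CO` — in this assay compound 2 gives 89000 nM.
Compound 3, `CC(C)CSc1nc(N)nc2c1ncn2/C=C1/CC1(CO)CO` — in this assay compound 3 gives 60000 nM.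

Compound 3 holds the lowest of the two readable numbers, and its nearest neighbour is compound 2, with a 1.5-fold lower number from compound 2 to compound 3 (0.17 log units; within the scatter). Among the compounds with values here, the only other value shown is the limit of compound 1, described by the limit of > 20000 nM in this assay, at which 1 of the 3 values shown sits.

The next compound is compound 4, `CCCCCOc1nc(N)nc2c1ncn2/C=C1/CC1(CO)CO`. It differs from compound 3 in this way: pentyloxy in place of isobutylsulfanyl on an aromatic carbon.

Within the data shown here, two measured steps bear on it. The step that the limit leaves unreadable from compound 1 to compound 3 already compares an alkoxy chain with a sulfanyl chain at the same aromatic carbon, but the limit of compound 1 makes its size unreadable. The step of a 1.5-fold lower number from compound 2 to compound 3 (0.17 log units; within the scatter) shows that changing the branching of the sulfanyl chain alone does not move this assay beyond the scatter. Given that the one alkoxy analogue, compound 1, sits at the limit, compound 4 is expected to land at or near that limit, with the step of a 1.2-fold lower number from compound 3 to compound 4 (0.08 log units; within the scatter) as the working estimate. Compound 4 is therefore estimated at 50000 nM, within a range from 15000 nM to 160000 nM.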

Compound 4, half-maximal cytotoxic concentration: > 20000 nM
Compound 4 ended at the assay's limit (the forecaster's own chance of this, stated with the estimate: 50%); the middle value is on the limit's open side.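

In this assay compound 4 gives > 20000 nM as a limit of the assay and not a number. No step to compound 4 from compound 1, compound 2 or compound 3 can be read: the limit of > 20000 nM in this assay, at which 2 of the 4 values shown sit.

In this assay the compounds shown leave open how far the pentyloxy and octyloxy compounds, compound 4 and compound 1, stand from the sulfanyl compounds, compound 2 and compound 3.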